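A Flat Series Meets a Trifluoromethyl Exchange

A few compounds are considered here, and "the series" means these few. Any claim that something is new, unique, unknown or untested is made for them only; others in the source may bear on it.

In a functional assay on NCI-H460 cells (Homo sapiens) for inhibition, read by MTT assay, with a stated time of 72 h (a lower number here means a stronger inhibitor, a higher number a weaker inhibitor), compound 1 (`COc1cc(NC(C)CCCNC(=O)Nc2ccc(F)cc2)c2ncccc2c1`) gives 26000 nM, compound 2 (`COc1cc(NC(C)CCCNC(=O)NNC(=O)Nc2ccc(Br)cc2)c2ncccc2c1`) gives 27000 nM, and compound 3 (`COc1cc(NC(C)CCCNC(=O)Nc2cccc(O)c2)c2ncccc2c1`) gives 25000 nM, so compound 3 lies within the scatter of both others. Compound 4 (`COc1cc(NC(C)CCCNC(=O)Nc2cccc(C(F)(F)F)c2)c2ncccc2c1`) carries trifluoromethyl in place of hydroxy on an aromatic carbon. Among the compounds with values here, no measured step makes this exact exchange. The closest evidence comes from changes to the group on the amide-type nitrogen: a 1.0-fold higher number from compound 1 to compound 2 (0.02 log units; within the scatter), a 1.0-fold lower number from compound 1 to compound 3 (0.02 log units; within the scatter) and a 1.1-fold lower number from compound 2 to compound 3 (0.03 log units; within the scatter), each within the scatter. Little change is therefore expected, with no step beyond the scatter. The expected step is a 1.3-fold lower number from compound 3 to compound 4 (0.10 log units; within the scatter). Compound 4 is estimated at 20000 nM, with an expected range of 9000 nM to 40000 nM.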

Compound 4, half-maximal inhibitory concentration: 21000 nM
Estimate against measurement, compound 4: 1.1-fold (0.02 log units) below; the measured number falls inside the stated range.
By their numbers in this assay, from the lowest: compounds 4, 3, 1 and 2 (each within the scatter of the next).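

In this assay, the exchange of hydroxy for trifluoromethyl on an aromatic carbon, meta to a large group, gives a 1.2-fold lower number from compound 3 to compound 4 (0.08 log units; within the scatter). This shows that the position tolerates the loss of the hydrogen-bond donor and acceptor counted for hydroxy, and the wider comparisons agree: a 1.2-fold lower number from compound 1 to compound 4 (0.09 log units; within the scatter) and a 1.3-fold lower number from compound 2 to compound 4 (0.11 log units; within the scatter). Nothing available here explains this flatness. The compounds shown leave open whether an amine or a carboxylic acid on this aromatic carbon would give a step beyond the scatter. From the compounds shown here alone, whether a longer chain would do so also remains open.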